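One Ring Exchange on a Shared Core

A few compounds are considered here, and "the series" means these few. Any claim that something is new, unique, unknown or untested is made for them only; others in the source may bear on it.

Of the compounds shown here, three have been measured in a functional assay on DU-145 cells (Homo sapiens) for inhibition, read by trypan blue exclusion, with a stated time of 96 h; on this read-out lower numbers stand for stronger inhibition of growth and higher numbers for weaker inhibition of growth. Compound 1 `Cc1cc(C)cc(/C=C(/SCc2ccc(F)cc2)C(=O)c2ccc(Br)cc2)c1` gives 10000 nM. Compound 2 `O=C(/C(=C\c1ccc(O)c([N+](=O)[O-])c1)SCc1ccc(Br)cc1)c1ccc(Br)cc1`, which carries a different ring at the same end of the core, gives 10000 nM. Compound 3 `O=C(/C(=C\c1ccc(O)cc1)S(=O)(=O)Cc1ccc(F)cc1)c1ccc(Br)cc1`, in which the sulfur link is oxidised, gives 10000 nM. On the digits shown compound 1 stands level with compound 2 and with compound 3; none of these pairs is separated by more than the usual scatter, so no order among them can be read from the numbers.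

Compound 4 `Cc1cc(F)ccc1/C=C(/SCc1ccc(F)cc1)C(=O)c1ccc(Br)cc1` has not yet been measured in this assay. It is derived from compound 1 by one change: 4-fluoro-2-methylphenyl in place of 3,5-dimethylphenyl on a double-bonded chain carbon bound to a double-bonded chain carbon. The change keeps the number of heavy atoms, the single aromatic ring of carbon, and the absence of donors, acceptors and charge; only one methyl gives way to a fluorine, and the remaining methyl moves to another position on that ring.

Nothing among the three measured compounds suggests that this kind of change moves the read-out, since compound 1, compound 2 and compound 3 sit together despite their different rings. The expected step of no change at the digits printed from compound 1 to compound 4 (within the scatter) is therefore none beyond the scatter. Compound 4 is expected to give about 10000 nM, with a plausible range from 4000 nM to 25000 nM.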

Compound 4, concentration for 50% growth inhibition: 10000 nM
Beside the measured number, compound 4's estimate shows no gap at the digits printed, and the stated range covers the measured number.
By their numbers in this assay, from the lowest: compounds 1, 2, 3 and 4 (each within the scatter of the next).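

In this assay, replacing 3,5-dimethylphenyl with 4-fluoro-2-methylphenyl on a double-bonded chain carbon bound to a double-bonded chain carbon gives no change at the digits printed from compound 1 to compound 4 (within the scatter). Among the compounds shown here, this is the first pair in the set that differs in one place only, so the read-out can now be followed across a single exchange at this position, whereas the earlier compounds differed from one another in more than one place. No separate measurement bearing on this result is available to explain it.

For the compounds shown here, this single pair covers only two substituted phenyl rings at this position, and a fluorine and a methyl are the only groups exchanged on that ring, so it sets no general rule for the position. How the read-out would respond to an amine or a carboxylic acid on this ring, or to a longer chain in place of the ring, remains open, and the compounds shown give no direction toward stronger inhibition of growth.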